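Moving the alkoxy group on the aryl piperazine of compound 3

This account rests on a few compounds, and the source may have more. Where it says the series, first, only, none or still open, it means among the compounds named here.

Measured so far:
compound 1, `O/N=C(\CCN1CCN(c2ccccn2)CC1)c1ccc(Cl)cc1`, gives 475 nM
compound 2, `N#Cc1cccnc1N1CCN(CC/C(=N/O)c2ccccc2)CC1`, gives 20 nM
compound 3, `CCO/N=C(\CCN1CCN(c2ccccc2OC)CC1)c1ccccc1`, gives 338 nM

All three compounds were tested in a functional assay on HEK293 cells with D(4) dopamine receptor (Homo sapiens) as the target, read by FLIPR; on this read-out higher numbers stand for an effect only at larger amounts of compound and lower numbers for an effect already at smaller amounts. Compound 3, with its value of 338 nM, stands second highest among the three numbers. Its nearest neighbour is compound 1, whose value of 475 nM lies within the usual scatter of compound 3, so the two cannot be told apart. Compound 2 is the furthest away: its value of 20 nM lies well below that of compound 3, a gap clearly beyond the scatter.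

Compound 4, `CCO/N=C(\CCN1CCN(c2cccc(OCC)c2)CC1)c1ccccc1`, is not yet measured. It differs from compound 3 in one place: 3-ethoxyphenyl in place of 2-methoxyphenyl on an amine nitrogen in a ring. Among the measured compounds shown here, no pair of measured compounds shows what this kind of change does in this assay, so nothing here tells how large a step to expect or in which direction. On that basis the expected step from compound 3 to compound 4 is a 1.2-fold higher number from compound 3 to compound 4 (0.07 log units; within the scatter), which is to say none beyond the scatter. The estimate for compound 4 in this assay is therefore 400 nM, with a range from 120 nM to 1300 nM.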

Compound 4, half-maximal effective concentration: 347 nM
Compound 4: the middle estimate sits 1.2-fold (0.06 log units) above what was measured; low and high end bracket the measured number.
By their numbers in this assay, from the lowest: compound 2; then compounds 3, 4 and 1 (each within the scatter of the next).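

In this assay the exchange of 2-methoxyphenyl for 3-ethoxyphenyl gives a 1.0-fold higher number from compound 3 to compound 4 (0.01 log units; within the scatter) and so leaves the read-out within the usual scatter. Among the compounds shown here, this is the first view of a change at this place, on an amine nitrogen in a ring, and it shows that this aryl group can be exchanged there, going from 8 to 9 heavy atoms, without a step beyond the scatter. No measurement at hand says why the two groups read alike.

This single step alters both the alkoxy chain and where it sits on the phenyl ring, so it cannot show what each alteration does alone, or whether two separate effects happen to offset each other. The compounds shown also leave open how this place would respond to an aryl group carrying an amine or a carboxylic acid, or a longer chain such as butoxy, any of which would show whether the flat result holds beyond these two alkoxy groups.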